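The source may report more compounds than this note shows. Statements on the series, on what has been measured and on what is new or still open speak of the compounds shown alone.

Measured compounds:
compound 1 `COc1ccc(C2C(C#N)=C(N)N(c3ccc(S(N)(=O)=O)cc3)C3=C2C(=O)CCC3)cc1` — 25 ug/mL
compound 2 `N#CC1=C(N)N(c2ccc(S(N)(=O)=O)cc2)C2=C(C(=O)CCC2)C1c1ccco1` — a limit only

In a functional assay on Ehrlich cells (Mus musculus) for antiproliferative activity, read by trypan blue exclusion, with a stated time of 2 h (on this read-out lower numbers stand for stronger inhibition and higher numbers for weaker inhibition), compound 1 gives 25 ug/mL, the only number shown in the series. Compound 2 reports only a limit, > 100 ug/mL, which is the limit of > 100 ug/mL in this assay, at which 1 of the 2 values shown sits. The step between them is an at least 4.0-fold higher number from compound 1 to compound 2 (0.60 log units; beyond the scatter). Compound 3 `Cc1ccoc1C1C(C#N)=C(N)N(c2ccc(S(N)(=O)=O)cc2)C2=C1C(=O)CCC2` differs from compound 1 by 3-methylfuran-2-yl in place of 4-methoxyphenyl on a saturated ring carbon. For the measured compounds named here, this change resembles the one leading to compound 2, where the five-membered ring gave a weaker result, so a step of the same direction is expected, with compound 3 likely near the limit. Compound 3 is therefore estimated at 80 ug/mL, between 30 ug/mL and 200 ug/mL, meaning a 3.2-fold higher number from compound 1 to compound 3 (0.51 log units; beyond the scatter).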

Compound 3, half-maximal inhibitory concentration: > 100 ug/mL
Compound 3 gave a limit, no number (the forecaster's own chance of this, stated with the estimate: 55%); middle value at least 1.2-fold (0.09 log units) from the limit.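

In this assay, 3-methylfuran-2-yl on the saturated ring carbon, like furan-2-yl, falls short of 4-methoxyphenyl: an at least 4.0-fold higher number from compound 1 to compound 3 (0.60 log units; beyond the scatter). Compound 3 reports a limit, not a number, and the series now collects at that ceiling: the limit of > 100 ug/mL in this assay, at which 2 of the 3 values shown sit. The step between compound 2 and compound 3 cannot be read, so the added methyl shows no readable effect.

Whether the methoxy group or the six-membered aromatic ring of compound 1 accounts for the difference stays open. Plain phenyl or 4-aminophenyl at this carbon would separate the two.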